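Working notes: from compound 3 to compound 4

This account rests on a few compounds, and the source may have more. Where it says the series, first, only, none or still open, it means among the compounds named here.

Compound 1 `CCOC(=O)c1ccc(Oc2ccc(OC)c(OC)c2)cc1`: > 20000 nM (limit)
Compound 2 `CCOC(=O)c1ccc(Oc2ccc(OC)cc2)cc1O`: > 30000 nM (limit)
Compound 3 `CCOC(=O)c1ccc(Oc2ccc(OC)c(F)c2)cc1O`: > 30000 nM (limit)

All three results in a functional assay on HL-60 cells (Homo sapiens) for antiproliferative activity (on this read-out higher numbers stand for weaker inhibition and lower numbers for stronger inhibition), are limits, so the series has no measured number yet. Compound 3 stands at > 30000 nM, which is a limit. It shares that limit with one other compound: the limit of > 30000 nM in this assay, at which 2 of the 3 values shown sit. The remaining result is the limit of > 20000 nM in this assay, at which 1 of the 3 values shown sits.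

Compound 4 `CCOC(=O)c1ccc(Oc2ccc(OC)c(OC)c2)cc1O` follows from compound 3 by one change: methoxy in place of fluoro on an aromatic carbon. In words, this is methoxy in place of fluoro on an aromatic carbon.

Among the compounds with values here, only one measured step bears on this position: a step that the two limits leave unreadable from compound 2 to compound 3. It gives no size to carry over, and it concerns a different exchange. With no readable step in this assay, there is no basis for expecting a change beyond the scatter in either direction. The expectation therefore rests on the limits themselves. Compound 3 at > 30000 nM is the starting point, and that value remains a limit.

The expected outcome is a number no higher from compound 3 to compound 4 (the limit leaves the size open). For compound 4 the estimated value is 30000 nM, with an expected range from 10000 nM to 60000 nM. A further limit is the more likely report.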

Compound 4, half-maximal inhibitory concentration: 1500 nM
Beside the measured number, compound 4's estimate is 20-fold (1.30 log units) above it; the measured number lies below the stated range.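

Within the data shown here, compound 4 is the first compound in this assay to give a measured number rather than a limit, and each of the other compounds lies one change away from it. Methoxy in place of fluoro gives an at least 20-fold lower number from compound 3 to compound 4 (1.30 log units; beyond the scatter) and methoxy in place of hydrogen gives an at least 20-fold lower number from compound 2 to compound 4 (1.30 log units; beyond the scatter) at the same position, ortho to a methoxy group, so here methoxy separates from both fluoro and hydrogen, which the earlier compounds could not show. Hydroxy in place of hydrogen gives an at least 13-fold lower number from compound 1 to compound 4 (1.12 log units; beyond the scatter) as well, so among these four compounds a measured number appears only where the hydroxy group and both methoxy groups occur together.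

Still open, on these data alone, is whether a longer ether such as ethoxy, or an amine, at the same position would keep a number of this order, and the step from compound 2 to compound 3 cannot be read. No measurement shown accounts for the change at this position.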